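The source may report more compounds than this note shows. Statements on the series, on what has been measured and on what is new or still open speak of the compounds shown alone.

Compound 1, with the structure `Cc1nc(C)n(CC(=O)N2CCN(c3sc(C(F)(F)F)nc3-c3nc4ccc(C5CCN(C)CC5)cc4[nH]3)C[C@H]2C)n1`, stands lowest of the two numbers measured in an ADME assay on microsomes from liver (Homo sapiens) for metabolic stability, read by LC-MS, using NADPH, with a stated time of 15 min, tested at 1 uM (a lower number here means slower removal, a higher number faster removal of the compound), where compound 1 gives 27 mL.min-1.g-1. Among the measured compounds shown here, the only other measured compound, compound 2, with the structure `C[C@@H]1CN(c2sc(C(F)(F)F)nc2-c2nc3ccc(CO)cc3[nH]2)CCN1C(=O)Cn1cnc2cccnc21`, gives in this assay a value of 131 mL.min-1.g-1, a higher number that lies beyond the usual scatter; the two compounds differ in several places at once, so their gap cannot be tied to a single change. Compound 3, with the structure `Cc1nc(C)n(CC(=O)N2CCN(c3sc(C(F)(F)F)nc3-c3nc4ccccc4[nH]3)C[C@H]2C)n1`, is not yet measured. It differs from compound 1 in one place: hydrogen in place of 1-methylpiperidin-4-yl on an aromatic carbon. For the measured compounds named here, no pair of measured compounds differs in just one place, so the size of this step is not known from the data. Starting from compound 1 at 27 mL.min-1.g-1, compound 3 is expected to show a modest rise in this assay, of about a 1.7-fold higher number from compound 1 to compound 3 (0.22 log units; within the scatter), a step that may still fall within the scatter. Compound 3 is thus estimated at 45 mL.min-1.g-1, with a range from 18 mL.min-1.g-1 to 110 mL.min-1.g-1.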

Compound 3, intrinsic clearance in microsomes: 30 mL.min-1.g-1
Compound 3: middle estimate off by 1.5-fold (0.18 log units), on the high side; the range from low to high includes it.
By their numbers in this assay, from the lowest: compounds 1 and 3 (each within the scatter of the next); then compound 2.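

In this assay, replacing the 1-methylpiperidin-4-yl on this aromatic carbon with hydrogen gives a 1.1-fold higher number from compound 1 to compound 3 (0.05 log units; within the scatter), so the two compounds cannot be told apart. This first single-place step shows that, on the core of compound 1, the whole ring-bearing group can be exchanged for hydrogen with no readable effect on the read-out of this assay. No measurement on hand explains this result.

What the compounds shown leave open is whether a different group on the same aromatic carbon, such as a carboxylic acid, a primary amine or a morpholine ring, would also leave the number within the scatter. From the compounds shown here alone, it also remains open whether the same exchange would be as silent on a compound that differs elsewhere from compound 1.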